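The source may report more compounds than this note shows. Statements on the series, on what has been measured and on what is new or still open speak of the compounds shown alone.

Going by the values given here, the three compounds measured so far share one core and differ only in the group carried on the amine nitrogen in the ring. Compound 1 `NC(=O)c1c(NC(=O)c2ccc(C(F)(F)F)cc2)sc2c1CCN(Cc1ccc(Cl)cc1)C2` bears a 4-chlorophenyl on a saturated chain carbon bound to that nitrogen. In a functional assay on MKN-74 cells (Homo sapiens) for antiproliferative activity, with a stated time of 24 h (a lower number here means a stronger inhibitor, a higher number a weaker inhibitor), compound 1 gives > 50000 nM, which is a limit of the assay and not a number. Compound 2 `NC(=O)c1c(NC(=O)c2ccc(C(F)(F)F)cc2)sc2c1CCN(Cc1c(Cl)cccc1Cl)C2` gives 8530 nM in this assay, and compound 3 `NC(=O)c1c(NC(=O)c2ccc(C(F)(F)F)cc2)sc2c1CCN(C(=S)Nc1ccccc1Cl)C2` gives 16400 nM. The step of an at least 5.8-fold lower number from compound 1 to compound 2 (0.76 log units; beyond the scatter) and the step of an at least 3.0-fold lower number from compound 1 to compound 3 (0.48 log units; beyond the scatter) both lie beyond the scatter, whereas the step of a 1.9-fold higher number from compound 2 to compound 3 (0.28 log units; within the scatter) does not, so compound 3 and compound 2 sit within the scatter of each other, while compound 1 is known only as a limit.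

Compound 4 `NC(=O)c1c(NC(=O)c2ccc(C(F)(F)F)cc2)sc2c1CCN(C(=O)Nc1ccccc1Cl)C2` has not been measured. It differs from compound 3 by a group of 10 heavy atoms (7 carbon, 1 nitrogen, 1 oxygen, 1 chlorine; one six-membered aromatic ring of carbon only) in place of a group of 10 heavy atoms (7 carbon, 1 nitrogen, 1 sulfur, 1 chlorine; one six-membered aromatic ring of carbon only), on an amine nitrogen in a ring. Among the compounds with values here, none of the measured steps matches this exchange: all three concern a change in what is carried on the amine nitrogen in the ring, not a like-for-like swap within an otherwise unchanged group, so no measured step bears on it directly. Compound 2 and compound 3 show that two rather different groups at this position give numbers within the scatter of each other. Compound 4 is therefore expected to show a 1.2-fold higher number from compound 3 to compound 4 (0.09 log units; within the scatter) in this assay, no step beyond the scatter. The estimate for compound 4 is 20000 nM, with an expected range from 7000 nM to 50000 nM.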

Compound 4, half-maximal inhibitory concentration: 43900 nM
Estimate against measurement, compound 4: 2.2-fold (0.34 log units) below; the measured number falls inside the stated range.
By their numbers in this assay, from the lowest: compounds 2 and 3 (each within the scatter of the next); then compound 4. At a limit, above all of these: compound 1.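

Going by these compounds alone, this exchange is the first at the amine nitrogen in a ring to leave the rest of the group unchanged. With (2-chlorophenyl)carbamoyl carrying oxygen where the group it replaces carries sulfur, this assay gives the step of a 2.7-fold higher number from compound 3 to compound 4 (0.43 log units; beyond the scatter), so this exchange alone moves the number beyond the scatter. Compound 2 and compound 3 had stood within the scatter of each other, but the 2,6-dichlorobenzyl and (2-chlorophenyl)carbamoyl groups do not, with a 5.1-fold higher number from compound 2 to compound 4 (0.71 log units; beyond the scatter). The step of an at least 1.1-fold lower number from compound 1 to compound 4 (0.05 log units; that floor lies within the scatter) gives only a floor, so it cannot be read as a difference. Compound 1 stands at a limit of the assay and not a number: the limit of > 50000 nM in this assay, at which 1 of the 4 values shown sits.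

As far as these compounds go, the sulfur and oxygen comparison rests on this one pair, so it remains open whether the same step would appear with a methyl or a methoxy group in place of the chlorine on the phenyl ring. The compounds shown also do not tell how an acetyl group or a longer alkyl chain between the nitrogen and the phenyl ring would compare at this position.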